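A few compounds are considered here, and "the series" means these few. Any claim that something is new, unique, unknown or untested is made for them only; others in the source may bear on it.

Compound 1 `CC1=C(C(=O)NC(C)C)C(c2ccoc2)NC(=O)N1` gives 1% in an assay on membranes from CHO cells for displacement of a labelled ligand from adenosine receptor A1 (Homo sapiens), read by scintillation counting, with a stated time of 60 min, tested at 1 uM; on this read-out higher numbers stand for more inhibition at the one concentration tested (going by the name of the read-out) and lower numbers for less inhibition. Compound 2 `CC1=C(C(=O)NC(C)C)C(c2ccsc2)NC(=O)N1` gives 8% in this assay; the step of a number 7 percentage points higher from compound 1 to compound 2 (within the scatter) concerns thiophen-3-yl in place of furan-3-yl on a saturated ring carbon. On these two numbers compound 2 and compound 1 lie within the scatter of each other, so neither stands apart. Compound 3 `CC1=C(C(=O)OCC2CC2)C(c2ccsc2)NC(=O)N1` differs from compound 2 as follows: cyclopropylmethoxy in place of isopropylamino on a carbonyl carbon. Among the measured compounds shown here, no measured step touches this carbonyl carbon, and the one step on record changes another place and lies within the scatter, so it gives no guidance. For compound 3 the expected step is no change at the digits printed from compound 2 to compound 3 (within the scatter), none beyond the scatter. Compound 3 is expected to give 8%, range -5% to 30%.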

Compound 3, a percentage reported as inhibition, at one concentration (the size of the read-out at that concentration, not a potency): 39%
For compound 3 the middle estimate is 31 percentage points below the measured one; measured number outside the range, above it.
By their numbers in this assay, from the lowest: compounds 1 and 2 (each within the scatter of the next); then compound 3.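

Cyclopropylmethoxy in place of isopropylamino on the carbonyl carbon gives a number 31 percentage points higher from compound 2 to compound 3 (beyond the scatter) in this assay, so this position, unlike the thiophen-3-yl for furan-3-yl change, can shift the read-out. Among the compounds shown here, the single change removes a hydrogen-bond donor, adds a hydrogen-bond acceptor and brings in a three-membered ring, and one step cannot separate these. No available evidence bears on the reason for the rise.

Still open, going by these compounds, is whether the oxygen link or the cyclopropylmethyl part carries the rise. Ethoxy or cyclopropylmethylamino on the same carbonyl carbon would separate the two.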